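Swapping the furan for cyclopropyl on the amide

The source may report more compounds than this note shows. Statements on the series, on what has been measured and on what is new or still open speak of the compounds shown alone.

Measured compounds:
compound 1 `CC(C)C(=O)N1CCc2cc(CNC(=O)c3ccc(Cl)cc3)ccc21` gives 92%
compound 2 `CC(C)CC(=O)N1CCc2cc(CNC(=O)c3ccco3)ccc21` gives 100%
compound 3 `CCC(=O)NCc1ccc2c(c1)CCN2C(=O)c1ccccc1` gives 41%

In an assay on HEK293 cells for inhibition of Indoleamine 2,3-dioxygenase 1 (Homo sapiens), tested at 10 uM (a higher number here means more inhibition at the concentration tested (going by the name of the read-out), a lower number less inhibition), compound 2 shows the largest number of the three, though compound 1 sits within the usual scatter of it, so the two cannot be told apart; compound 3 lies clearly lower. Compound 4 `CC(C)CC(=O)N1CCc2cc(CNC(=O)C3CC3)ccc21` has not been measured. Compared with compound 2 the change is cyclopropyl in place of furan-2-yl on a carbonyl carbon, on the carbonyl carbon next to the amide-type nitrogen. Among the measured compounds shown here, no measured pair isolates this change, so the expected step in this assay rests on a loose reading: some loss is expected, since the aromatic ring gives way to a small saturated one. Compound 4 is estimated at 75%, between 50% and 95%, a step of a number 25 percentage points lower from compound 2 to compound 4 (beyond the scatter) expected to be modest.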

Compound 4, a percentage reported as inhibition, at one concentration (the size of the read-out at that concentration, not a potency): 35%
Estimate against measurement, compound 4: 40 percentage points above, outside the stated range (below it).
By their numbers in this assay, from the lowest: compounds 4 and 3 (each within the scatter of the next); then compounds 1 and 2 (each within the scatter of the next).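

Among the compounds shown here, this is the first pair in the set that differs in only one place, and it shows that the group on this carbonyl carbon, whose other neighbour is the amide-type nitrogen, matters strongly. In this assay, cyclopropyl in place of furan-2-yl gives a step of a number 65 percentage points lower from compound 2 to compound 4 (beyond the scatter) and so does not stand in for the furan here. For the compounds shown here, nothing measured so far explains this loss. Still open, going by these compounds, is whether the ring must be aromatic or merely larger, a question that cyclopentyl or thiophen-2-yl on the same carbonyl carbon could help to settle.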